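This account rests on a few compounds, and the source may have more. Where it says the series, first, only, none or still open, it means among the compounds named here.

Compound 1 `O=C(c1ccc(F)cc1)N1CC(c2nc(-c3cccc(Cl)c3)no2)C1`: > 10000 nM
Compound 2 `O=C(C1CCC1)N1CC(c2nc(-c3cccc(Cl)c3)no2)C1`: > 10000 nM

Both measured compounds share one core and differ only in the group attached to the carbonyl carbon. In an assay on HEK293 cells for positive allosteric modulation of metabotropic glutamate receptor 5 (Homo sapiens), read by FLIPR (a higher number here means that more compound is needed for the effect, a lower number that less compound is needed), compound 1 gives > 10000 nM, which is a limit of the assay rather than a number. In this assay compound 2 gives > 10000 nM, again a limit and not a number. The step that the two limits leave unreadable from compound 1 to compound 2 therefore cannot be read in size or direction, since both compounds sit at the limit of > 10000 nM in this assay, at which 2 of the 2 values shown sit. Compound 2 thus stands at the limit, with no number of its own to compare against.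

Compound 3 `CC1CCN(C(=O)N2CC(c3nc(-c4cccc(Cl)c4)no3)C2)C1` differs from compound 2 by 3-methylpyrrolidin-1-yl in place of cyclobutyl on a carbonyl carbon. Going by the values given here, the only measured step, from compound 1 to compound 2, concerns a change at the same carbonyl carbon, yet its size is unreadable, so it offers no pointer in either direction. With no readable step to build on, no movement beyond the scatter is expected, and the step of a number no higher from compound 2 to compound 3 (the limit leaves the size open) is expected to be small. Compound 3 is therefore estimated at 10000 nM, with a limit rather than a number being the most likely outcome.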

Compound 3, half-maximal effective concentration: > 10000 nM
Compound 3: a limit, no number (the forecaster's own chance of this, stated with the estimate: 70%); the middle value lies on the limit itself.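

In this assay compound 3 gives > 10000 nM as a limit and not a number. The steps from compound 1 and compound 2 to compound 3 therefore cannot be read, as all three compounds sit at one limit: the limit of > 10000 nM in this assay, at which 3 of the 3 values shown sit.

The compounds shown leave open whether any group on the carbonyl carbon of the shared core gives a measurable value, and how far these three lie apart.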